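The source may report more compounds than this note shows. Statements on the series, on what has been measured and on what is new or still open speak of the compounds shown alone.

Compound 1 `C/C(=C\C(=O)Nc1ccc2nc(N3CCC(O)(C4CC4)CC3)nc(C)c2c1)c1ccc(Cl)cc1` gives 340 nM in a functional assay on CHO-K1 cells for antagonist activity at melanin-concentrating hormone receptor 1 (Homo sapiens), read by inositol phosphate accumulation, with stated times of 10 min and 45 min (a lower number here means a stronger inhibitor, a higher number a weaker inhibitor), the highest of the three numbers to hand. Compound 2 `C/C(=C\C(=O)Nc1ccc2nc(N3CCC(O)CC3)nc(C)c2c1)c1ccc(Cl)cc1` gives 227 nM; a 1.5-fold lower number from compound 1 to compound 2 (0.18 log units; within the scatter), so the two are not ordered. Compound 3 `Cc1nc(N2CCC(N3CCCC3=O)CC2)nc2ccc(NC(=O)/C=C/c3ccc(OC(F)(F)F)cc3)cc12` gives 12 nM, far lower than compound 1. Compound 4 `Cc1nc(N2CCC(O)(C3CC3)CC2)nc2ccc(NC(=O)/C=C/c3ccc(C(F)(F)F)cc3)cc12` differs from compound 1 by 2-(4-(trifluoromethyl)phenyl)ethenyl in place of 2-(4-chlorophenyl)prop-1-en-1-yl on a carbonyl carbon. For the measured compounds named here, no measured step touches the carbonyl carbon: a 1.5-fold lower number from compound 1 to compound 2 (0.18 log units; within the scatter) concerns a saturated ring carbon and is within the scatter, so it does not bear directly on this change. Compound 3 carries an ethenyl-linked amide side resembling that of compound 4 but also differs elsewhere, so its value can only hint. A lower number is expected for compound 4, a 5.7-fold lower number from compound 1 to compound 4 (0.75 log units; beyond the scatter), because compound 3 gives 12 nM. The estimate for compound 4 is 60 nM, within 15 nM to 240 nM.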

Compound 4, half-maximal inhibitory concentration: 83 nM
Compound 4: the middle estimate sits 1.4-fold (0.14 log units) below what was measured, and the stated range covers the measured number.
By their numbers in this assay, from the lowest: compound 3; then compound 4; then compounds 2 and 1 (each within the scatter of the next).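

At the carbonyl carbon, 2-(4-(trifluoromethyl)phenyl)ethenyl in place of 2-(4-chlorophenyl)prop-1-en-1-yl gives a 4.1-fold lower number from compound 1 to compound 4 (0.61 log units; beyond the scatter) in this assay and is the only step shown at this position, with the rest of compound 1 unchanged. Unlike the step at the saturated ring carbon, it lies beyond the scatter. The swap changes the ring substituent and the alkene chain together, so the step cannot be assigned to either part, and no measurement here explains it.

Still open, going by these compounds, is how a nitrile in place of the trifluoromethyl would compare on the same ethenyl chain.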